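This account rests on a few compounds, and the source may have more. Where it says the series, first, only, none or still open, it means among the compounds named here.

Working notes on the sulfonylurea and sulfonylthiourea pair.

Compound 1 `Cc1cc(C(=O)O)nn1-c1ccc(S(=O)(=O)NC(=O)NCc2ccccc2)cc1` carries a carboxylic acid on the shared core; in a functional assay on the whole organism (blood, strain albino) with Mus musculus as the target, with stated times of 6 days and 4 h, at a dose of 0.4 mmol/kg by the oral route (a lower number here means less inhibition, a higher number more inhibition at the dose given (going by the name of the read-out)), compound 1 gives 0%. Compound 2 `Cc1cc(C)n(-c2ccc(S(=O)(=O)NC(=S)NCc3ccccc3)cc2)n1` replaces that acid with a second methyl on the core and swaps the carbonyl of the urea bridge for a thiocarbonyl; in this assay compound 2 gives 0%. On the numbers shown compound 2 stands level with compound 1 at the digits recorded, with no difference beyond the scatter, so neither member of the measured pair shows any inhibition in this assay at this dose.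

Compound 3 `CCCCNC(=S)NS(=O)(=O)c1ccc(-n2nc(C)cc2C)cc1` is the next entry and has not yet been run. Relative to compound 2 the change is propyl in place of phenyl on a saturated chain carbon bound to an amide-type nitrogen. For the measured compounds named here, no measured step between two compounds exists here, so the size of this step is not known from data.

Going by the values given here, with compound 2 at a reading of no inhibition in this assay and no measured step to lean on, the step from compound 2 to compound 3 is expected to be none beyond the scatter, that is no change at the digits printed from compound 2 to compound 3 (within the scatter). Compound 3 is therefore estimated at 0% in this assay, with a range from 0% to 10%.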

Compound 3, a percentage reported as inhibition, in the whole organism at one dose (the size of the read-out at that dose, not a potency): 1%
The estimate for compound 3 lay 1 percentage points below the measured number, and the stated range covers the measured number.
By their numbers in this assay, from the lowest: compounds 1, 2 and 3 (each within the scatter of the next).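

In this assay, propyl in place of phenyl on a saturated chain carbon bound to an amide-type nitrogen gives a number 1 percentage points higher from compound 2 to compound 3 (within the scatter), the first step read at this position in the series. The open butyl chain of compound 3 and the benzyl group of compound 2 therefore cannot be told apart at this dose, and the loss of the aromatic ring leaves no mark on the reading; with both compounds lying so close to no inhibition, however, the step cannot show how these two groups would compare on a compound with a clear effect. No accompanying measurement bears on this result, so nothing can be said about what lies behind it.

Still open, from the compounds shown here alone, is whether any group at this position, such as a longer chain, a cyclohexyl ring or a chain ending in an amine, can lift the reading beyond the scatter. Also open, going by these compounds, are the separate contributions of the carboxylic acid and the thiocarbonyl, which differ together between compound 1 and compound 2 and so cannot be read apart.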